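The source may report more compounds than this note shows. Statements on the series, on what has been measured and on what is new or still open speak of the compounds shown alone.

Measured compounds:
compound 1, `O=C(Nc1ccc(Cl)c(Cl)c1)Nc1ncccc1O`: > 20000 nM
compound 2, `O=C(Nc1cc(C(F)(F)F)cc(C(F)(F)F)c1)Nc1ncccc1O`: 14800 nM

Both were tested in a functional assay on cells (Mus musculus) for antiproliferative activity, read by sulforhodamine B assay, with a stated time of 5 days; a lower number here means a stronger inhibitor, a higher number a weaker inhibitor. For compound 1 the result is only a limit of the assay, > 20000 nM, not a number, so where compound 1 stands among the values shown is given by the limit of > 20000 nM in this assay, at which 1 of the 2 values shown sits. Compound 2, which carries two trifluoromethyl groups on the same outer ring, gives 14800 nM in this assay.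

Compound 3, `O=C(Nc1ccc(Cl)c(C(F)(F)F)c1)Nc1ncccc1O`, has not yet been measured in this assay. It differs from compound 1 in one place: trifluoromethyl in place of chloro on an aromatic carbon. Going by the values given here, no measured pair shows this exact change, so the size of its effect is unknown. Given the limit of compound 1 and the value of compound 2, the expected step from compound 1 to compound 3 is an at least 1.1-fold lower number from compound 1 to compound 3 (0.04 log units; that floor lies within the scatter), which may not exceed the usual scatter. The estimate for compound 3 in this assay is 18000 nM, within a range from 6000 nM to 40000 nM.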

Compound 3, half-maximal inhibitory concentration: 15400 nM
The estimate for compound 3 lay 1.2-fold (0.07 log units) above the measured number; measured number inside the range.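

On this aromatic carbon, ortho to a chloro group, trifluoromethyl in place of chloro now has a measured result in this assay, and the change gives an at least 1.2-fold lower number from compound 1 to compound 3 (0.11 log units; that floor lies within the scatter). Compound 1 is recorded only as a limit of the assay, > 20000 nM. The step is therefore only a floor, so the true size of the change stays unknown, and the comparison rests on this limit: the limit of > 20000 nM in this assay, at which 1 of the 3 values shown sits.

The compounds shown leave open whether another group on this carbon, such as an amine, a carboxylic acid or a longer carbon chain, would move the number beyond the scatter. Going by these compounds alone, they also leave open whether the same exchange would give a similar step elsewhere on the ring, since only this one pair shows it.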